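Saturating a Long Chain on Two Related Cores

The source may report more compounds than this note shows. Statements on the series, on what has been measured and on what is new or still open speak of the compounds shown alone.

Compound 1 `CCCCCCCC/C=C\CCCCCCCCOc1cc(O)c(C(C)=O)c(O)c1`: 31000 nM
Compound 2 `CCCCCCCC/C=C\CCCCCCCCOc1cc(O)cc(O)c1C(C)=O`: > 100000 nM (a limit of the assay)
Compound 3 `CCCCCCCCCCCCCCCCCCOc1cc(O)c(C(C)=O)c(O)c1`: > 100000 nM (a limit of the assay)

All three were tested in a functional assay on A549 cells (Homo sapiens) for cytotoxicity, read by XTT assay, with a stated time of 72 h; on this read-out lower numbers stand for stronger inhibition and higher numbers for weaker inhibition. Among the compounds with values here, compound 1 is the only one with a number; for compound 2 the assay reports only a limit, and for compound 3 likewise. Two of the three results therefore sit at the limit of > 100000 nM in this assay, at which 2 of the 3 values shown sit.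

Compound 1 and compound 2 share the same atoms joined differently; the difference between the two cores is not broken down here. Compound 3 arises from compound 1 through (decyl in place of dec-1-en-1-yl on a saturated chain carbon, eight bonds along the chain from an oxygen on an aromatic ring), and the same change turns compound 2 into compound 4 `CCCCCCCCCCCCCCCCCCOc1cc(O)cc(O)c1C(C)=O`, which has not yet been measured: decyl in place of dec-1-en-1-yl on a saturated chain carbon, eight bonds along the chain from an oxygen on an aromatic ring. In this assay the change gave an at least 3.2-fold higher number from compound 1 to compound 3 (0.50 log units; beyond the scatter).

Since compound 2 already sits at the limit, compound 4 is expected to remain there as well; the expected step is a step that the limit leaves unreadable from compound 2 to compound 4, resting on the direction seen for compound 1 and compound 3. The estimate for compound 4 is 200000 nM, spanning 60000 nM to 800000 nM.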

Compound 4, half-maximal inhibitory concentration: > 100000 nM
Compound 4 gave a limit, no number; the forecaster's own chance of this, stated with the estimate: 90%; the middle value is on the limit's open side.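

Compound 2 and compound 4 both give only a limit rather than a number, so no step between them can be read, and the comparison ends at: the limit of > 100000 nM in this assay, at which 3 of the 4 values shown sit.

The compounds shown leave open whether decyl in place of dec-1-en-1-yl changes anything in this assay on the core of compound 2, as it did on the core of compound 1.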